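The compounds below may be only part of what the source reports. "The series", "measured", "known", "first", "only" and "open" are said of these compounds alone.

Measured compounds:
- compound 1, `COC(=O)c1cnc(Oc2ccc3c(c2)B(O)OC3)cn1`: 7590 nM
- compound 2, `CCNC(=O)c1cnc(Oc2ccc3c(c2)B(O)OC3)cn1`: 79900 nM
- compound 3, `CCOC(=O)c1cnc(Oc2ccc3c(c2)B(O)OC3)cn1`: 16800 nM

All three share one core and differ only in the group hanging from the carbonyl carbon. In an ADME assay on Jurkat cells (Homo sapiens) for cytotoxicity, read by MTT assay, with a stated time of 72 h (a lower number here means a stronger inhibitor, a higher number a weaker inhibitor), compound 3 stands second highest of the three numbers. Its nearest neighbour is compound 1, with a 2.2-fold higher number from compound 1 to compound 3 (0.35 log units; beyond the scatter) separating them, and its furthest is compound 2, with a 4.8-fold lower number from compound 2 to compound 3 (0.68 log units; beyond the scatter) between that pair. Compound 4, `O=C(OC1CCCCC1)c1cnc(Oc2ccc3c(c2)B(O)OC3)cn1`, takes the ester of compound 3 one step further: cyclohexyl in place of ethyl on an oxygen next to a carbonyl group.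

Going by the values given here, only one measured step bears on this kind of change, the lengthening of the ester chain from compound 1 to compound 3, which gave a 2.2-fold higher number from compound 1 to compound 3 (0.35 log units; beyond the scatter). That step was modest and pointed towards a higher number. The change to compound 4 adds far more carbon than that step did, yet nothing measured here shows what a ring on the ester oxygen does. A further modest rise in this assay is therefore the cautious expectation, with a wide margin on either side. Compound 4 is expected to give about 25000 nM, within a range from 8000 nM to 80000 nM. That estimate means a step of a 1.5-fold higher number from compound 3 to compound 4 (0.17 log units; within the scatter) is expected.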

Compound 4, half-maximal inhibitory concentration: 52400 nM
Beside the measured number, compound 4's estimate is 2.1-fold (0.32 log units) below it; measured number inside the range.
By their numbers in this assay, from the lowest: compound 1; then compound 3; then compounds 4 and 2 (each within the scatter of the next).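

In this assay, the oxygen of the ester tolerates a ring, and the number keeps climbing as the group on that oxygen grows from methyl to ethyl to cyclohexyl (a 3.1-fold higher number from compound 3 to compound 4 (0.49 log units; beyond the scatter); a 6.9-fold higher number from compound 1 to compound 4 (0.84 log units; beyond the scatter)), with no ester among compounds 1, 3 and 4 going against this order. The earlier compounds shown here showed both esters clearly lower than the ethylamino compound, whereas cyclohexyloxy cannot be told apart from ethylamino in this assay (a 1.5-fold lower number from compound 2 to compound 4 (0.18 log units; within the scatter)), so an ester can reach the same level once its group is large enough. Nothing measured here explains why these groups shift the number.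

On these data alone, whether the ring itself matters, or only the added carbon, remains open, a question that a straight hexyl chain on the oxygen could address. Also open, as far as these compounds go, is what a carboxylic acid or a cyclohexylamino group on the carbonyl carbon would give, the latter joining the same ring to the nitrogen link of compound 2.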